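The source may hold more compounds than are shown below. What is called first, only, known or untested is meant among the compounds shown, and "the series" means these compounds.

In a functional assay on A-431 cells (Homo sapiens) for antiproliferative activity, read by MTT assay, with a stated time of 72 h (on this read-out lower numbers stand for stronger inhibition and higher numbers for weaker inhibition), compound 1 `CN1CCN(Cc2ccc(NC(=O)Nc3ccc4ncnc(Nc5cccc(C(F)(F)F)c5)c4c3)cc2)CC1` gives 2410 nM, the lowest of the two numbers shown. Compound 2 `COC(=O)c1cccc(Nc2ncnc3ccc(NC(=O)Nc4ccc(CN5CCN(C)CC5)cc4)cc23)c1` gives 5630 nM, and the step of a 2.3-fold higher number from compound 1 to compound 2 (0.37 log units; beyond the scatter) comes from methoxycarbonyl replacing trifluoromethyl on an aromatic carbon. Compound 3 `CN1CCN(Cc2ccc(NC(=O)Nc3ccc4ncnc(Nc5cccc(C(=O)N6CCCC6)c5)c4c3)cc2)CC1` reaches only the limit of this assay, > 10000 nM (the limit of > 10000 nM in this assay, at which 1 of the 3 values shown sits). The step of an at least 4.1-fold higher number from compound 1 to compound 3 (0.61 log units; beyond the scatter) is the one in which (pyrrolidin-1-yl)carbonyl stands in place of trifluoromethyl on an aromatic carbon. Compound 4 `O=C(Nc1ccc(CN2CCCCC2)cc1)Nc1ccc2ncnc(Nc3cccc(C(F)(F)F)c3)c2c1` differs from compound 1 at another place entirely: piperidin-1-yl in place of 4-methylpiperazin-1-yl on a saturated chain carbon bound to an aromatic carbon. Among the measured compounds shown here, none of the measured steps alters this part of the molecule, so no direct guide exists for its size. The step of a 1.0-fold higher number from compound 1 to compound 4 (0.02 log units; within the scatter) is therefore expected to stay within the usual scatter, in no clear direction. Compound 4 is estimated at 2500 nM, with a range from 1200 nM to 6000 nM.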

Compound 4, half-maximal inhibitory concentration: 1550 nM
Estimate against measurement, compound 4: 1.6-fold (0.21 log units) above; the range from low to high includes it.
By their numbers in this assay, from the lowest: compounds 4 and 1 (each within the scatter of the next); then compound 2. At a limit, above all of these: compound 3.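

This is the first change shown at the far end of the molecule from the trifluoromethyl group: with piperidin-1-yl on the saturated chain carbon, this assay gives a 1.6-fold lower number from compound 1 to compound 4 (0.19 log units; within the scatter). A ring with one nitrogen can therefore replace the 4-methylpiperazin-1-yl ring with two without a shift beyond the scatter, unlike the replacements of trifluoromethyl in compound 2 and compound 3. Nothing available here accounts for this small step. On these data alone, whether morpholin-4-yl or an open-chain dimethylamino group on the same carbon would also leave the number within the scatter stays open. So does whether piperidin-1-yl would behave alike with methoxycarbonyl in place of trifluoromethyl.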